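This account rests on a few compounds, and the source may have more. Where it says the series, first, only, none or still open, it means among the compounds named here.

Measured compounds:
compound 1 `Cc1ccc(S(=O)(=O)N2C=CNC(=O)[C@H]2CC(=O)N[C@H]2CCN(CC(C)(C)C)CC2(C)C)cc1` — 1.38 nM
compound 2 `CN(C)[C@H]1CCN(C(=O)C[C@@H]2C(=O)NC=CN2S(=O)(=O)c2cccc(Cl)c2Cl)C1` — 20.3 nM
compound 3 `Cc1cc(S(=O)(=O)N2C=CNC(=O)[C@H]2CC(=O)N2CCC(N(C)C)CC2)c(C)cc1Cl` — 152 nM

In an in vitro functional assay on cells for antagonist activity at B1 bradykinin receptor (Homo sapiens), read by luminescence and calcium flux, with a stated time of 2 h (a higher number here means a weaker inhibitor, a lower number a stronger inhibitor), compound 3 gives the highest number of the three, a gap beyond the usual scatter to compound 2 and a far larger one to compound 1, so compound 3 is the weakest inhibitor in this set. Compound 4 `Cc1cc(S(=O)(=O)N2C=CNC(=O)[C@H]2CC(=O)N2CCCCC(N(C)C)CC2)c(C)cc1Cl` is not yet measured. It differs from compound 3 in one place: a group of 11 heavy atoms (9 carbon, 2 nitrogen; one eight-membered non-aromatic ring with 1 hetero atom) in place of a group of 9 heavy atoms (7 carbon, 2 nitrogen; one six-membered non-aromatic ring with 1 hetero atom), on a carbonyl carbon. The group that leaves is the 4-(dimethylamino)piperidin-1-yl; what enters has no common name and keeps the same count of donors and acceptors, the ring growing from six to eight members.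

Within the data shown here, no step between measured compounds covers a change of this kind, so the direction rests on the structural change alone. The author expects no step beyond the scatter, or at most a small one toward a higher number, since every measured compound keeps the six-membered ring at this carbonyl. For compound 4 the expected step from compound 3 is a 1.6-fold higher number from compound 3 to compound 4 (0.22 log units; within the scatter). Compound 4 is estimated at 250 nM, in the range 80 nM to 800 nM.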

Compound 4, half-maximal inhibitory concentration: 4.75 nM
For compound 4 the middle estimate is 53-fold (1.72 log units) above the measured one; measured number outside the range, below it.
By their numbers in this assay, from the lowest: compound 1; then compound 4; then compound 2; then compound 3.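

In this assay, placing the eight-membered ring on the carbonyl carbon in place of the 4-(dimethylamino)piperidin-1-yl gives a 32-fold lower number from compound 3 to compound 4 (1.51 log units; beyond the scatter) and shows that this position responds strongly to ring size. Among these compounds, the earlier compounds could not show this, since no two of them differ in one place only, and this is the first single change read at this carbonyl carbon. Nothing measured here accounts for the size of the step.

Going by these compounds, whether a seven-membered ring at the same carbonyl carbon would give a number nearer to that of compound 3 or compound 4 remains open. On these data alone, it is also open whether the larger ring keeps its effect if its dimethylamino group gives way to a primary amine or a carboxylic acid, or if the aryl sulfonyl group of compound 4 changes.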